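The source may report more compounds than this note shows. Statements on the series, on what has been measured and on what is new or still open speak of the compounds shown alone.

Measured compounds and their values:
compound 1 `O=C(Nc1ccc(Cl)cc1)C1CCCN(C(=O)c2cccc(-c3nccs3)c2)C1` gives 32%
compound 2 `CSc1cccc(NC(=O)C2CCCN(C(=O)c3cc(C(F)(F)F)cc(C(F)(F)F)c3)C2)c1` gives 0%
compound 3 `C=CCOc1cccc(NC(=O)C2CCCN(C(=O)c3cc(C(F)(F)F)cc(C(F)(F)F)c3)C2)c1` gives 0%

All three were run in an ADME assay on PC-3 cells (Homo sapiens) for cytotoxicity, read by WST assay, tested at 100 uM; on this read-out lower numbers stand for less inhibition and higher numbers for more inhibition at the one concentration tested (going by the name of the read-out). Compound 1 stands highest of the three numbers; compound 2 lies a number beyond the scatter lower, and compound 3 lies the same distance lower. Compounds 2 and 3 share the bis(trifluoromethyl) acyl part, so their two numbers show only that neither gives inhibition at this concentration. Going by the values given here, the one single-point step available is no change at the digits printed from compound 2 to compound 3 (within the scatter); it concerns the anilide ring, not the acyl ring, and does not bear on the change considered here.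

The next compound is compound 4 `CCN(CC)S(=O)(=O)c1cccc(C(=O)N2CCCC(C(=O)Nc3ccc(Cl)cc3)C2)c1`. It differs from compound 1 in one place: diethylsulfamoyl in place of 1,3-thiazol-2-yl on an aromatic carbon. Among the compounds with values here, no measured pair changes the substituent on the acyl ring, so no step of known size can be carried over; the expectation rests on compound 1 alone as the closest point, with the spread of the other two as a reminder that inhibition in this assay can drop to nothing.

The estimate for compound 4 is therefore a step of a number 10 percentage points lower from compound 1 to compound 4 (within the scatter), expected to lie within or near the scatter, leaning lower. Compound 4 is expected to give 22%, within a range from 0% to 50%.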

Compound 4, a percentage reported as inhibition, at one concentration (the size of the read-out at that concentration, not a potency): 0%
Compound 4: the middle estimate sits 22 percentage points above what was measured; measured number inside the range.
By their numbers in this assay, from the lowest: compounds 2, 3 and 4 (each within the scatter of the next); then compound 1.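

In this assay, going by these compounds alone, the substituent at this place on the acyl ring proves able to set the read-out on its own: with the rest of compound 1 unchanged, diethylsulfamoyl in place of 1,3-thiazol-2-yl gives a number 32 percentage points lower from compound 1 to compound 4 (beyond the scatter), the only measured change at this position. The exchange swaps a five-membered aromatic ring with 2 hetero atoms for a larger group with no ring, while the counts of hydrogen-bond donors and acceptors stay the same, so the step does not follow a difference in those counts. This single pair changes ring, size and atom types together and cannot separate them, and nothing available explains the step.

Going by these compounds, it remains open whether the inhibition seen with compound 1 depends on the 1,3-thiazol-2-yl group specifically or would persist with another aromatic ring at this place, such as phenyl, pyridine or oxazole. A smaller sulfonyl group, such as methylsulfonyl or an unsubstituted sulfamoyl, would show whether the loss belongs to the sulfonyl unit or to its two ethyl chains.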